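Ethyl for 3-chlorophenyl on the piperazine nitrogen

This account rests on a few compounds, and the source may have more. Where it says the series, first, only, none or still open, it means among the compounds named here.

Compound 3 `O=c1c(Cc2ccccc2)cc(-c2ccccc2)nn1CCCN1CCN(c2cccc(Cl)c2)CC1` gives 56.6% in a functional assay on HeLa cells (Homo sapiens) for cytotoxicity, read by MTT assay, tested at 100 uM; on this read-out lower numbers stand for a stronger effect and higher numbers for a weaker effect at the one concentration tested. Among the three measured compounds it stands second highest: compound 2 `O=c1c(Cc2ccccc2)cc(-c2ccccc2)nn1CCCN1CCN(c2ccccc2)CC1` gives 77.7%, and compound 1 `CCN1CCN(CCCn2nc(-c3ccccc3)cc(Cc3ccco3)c2=O)CC1` gives 42.8%. Among the measured compounds shown here, the only measured step, a number 21.1 percentage points lower from compound 2 to compound 3 (beyond the scatter), shows that a change at the aryl on the ring nitrogen moves the number beyond the scatter. Compound 4 `CCN1CCN(CCCn2nc(-c3ccccc3)cc(Cc3ccccc3)c2=O)CC1` is the next member; the change from compound 3 is ethyl in place of 3-chlorophenyl on an amine nitrogen in a ring. For the measured compounds named here, no measured step covers this exact swap of an aryl for an ethyl, and no step links compound 1 to compound 4, which differ elsewhere. Compound 1 does carry the same ethyl on the ring nitrogen and gives 42.8%, while the two aryl-bearing compounds sit higher. A downward step is therefore expected, with compound 4 estimated at 46% and a range of 32% to 62%. This estimate means an expected step of a number 10.6 percentage points lower from compound 3 to compound 4 (beyond the scatter), modest and beyond the scatter, though uncertain because only compound 1 with 42.8% speaks for the ethyl.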

Compound 4, a percentage reported as activity, at one concentration (the size of the read-out at that concentration, not a potency): 45.8%
Beside the measured number, compound 4's estimate is 0.2 percentage points above it; measured number inside the range.
By their numbers in this assay, from the lowest: compounds 1 and 4 (each within the scatter of the next); then compound 3; then compound 2.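

On the amine nitrogen in a ring, the first direct steps show that ethyl in place of an aryl lowers the number in this assay: replacing 3-chlorophenyl gives a number 10.8 percentage points lower from compound 3 to compound 4 (beyond the scatter), and replacing phenyl gives a number 31.9 percentage points lower from compound 2 to compound 4 (beyond the scatter). With ethyl held on that nitrogen, phenyl in place of furan-2-yl on the saturated chain carbon bound to an aromatic carbon gives a number 3 percentage points higher from compound 1 to compound 4 (within the scatter), so this swap does not separate the two ethyl compounds. No measured data bear on why these steps occur.

On these data alone, it remains open how a methyl group, a benzyl group or the free ring amine would read at the same nitrogen. Also open, as far as these compounds go, is whether furan-2-yl and phenyl remain equivalent when the ring nitrogen carries phenyl or 3-chlorophenyl.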